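This account rests on a few compounds, and the source may have more. Where it says the series, first, only, none or still open, it means among the compounds named here.

Measured compounds:
compound 1 `COCCN(C)S(=O)(=O)c1ccc(C)c(C#Cc2cc(Cl)ccc2OCC(=O)O)c1` gives 4.1 nM
compound 2 `CCCS(=O)(=O)c1ccc(C)c(C#Cc2cc(Cl)ccc2OC(CC(C)C)C(=O)O)c1` gives 515 nM
compound 3 `CN(C)S(=O)(=O)c1cccc(C#Cc2cc(Cl)ccc2OCC(=O)O)c1` gives 14 nM

All three numbers come from an assay on CHO cells for displacement of a labelled ligand from prostaglandin D2 receptor 2 (Homo sapiens), read by scintillation counting; on this read-out higher numbers stand for weaker inhibition and lower numbers for stronger inhibition. Compound 1 has the lowest number of the three, and its separation from both compound 3 and compound 2 is beyond the usual scatter. Compound 2 is far from the other two. No pair of these compounds differs in just one place, so none of them sets a one-step reference for what follows.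

Compound 4 `Cc1ccc(S(C)(=O)=O)cc1C#Cc1cc(Cl)ccc1OCC(=O)O` has not yet been measured. Relative to compound 1 it carries the change (methyl in place of (2-methoxyethyl)(methyl)amino on a sulfonyl sulfur). Among the measured compounds shown here, since no measured pair follows the same change, the direction and size of the step rest on the structural change itself and on the standing of compound 1. The expectation is a small step toward a higher number in this assay for compound 4, close to the edge of the scatter, so possibly no change at all. The step from compound 1 is estimated at a 2.0-fold higher number from compound 1 to compound 4 (0.29 log units; within the scatter). Compound 4 is therefore expected at 8 nM, within a range of 2.5 nM to 30 nM.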

Compound 4, inhibition constant: 5 nM
Compound 4: middle estimate off by 1.6-fold (0.20 log units), on the high side; the range from low to high includes it.
By their numbers in this assay, from the lowest: compounds 1 and 4 (each within the scatter of the next); then compound 3; then compound 2.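

In this assay, among the compounds shown here, methyl in place of (2-methoxyethyl)(methyl)amino on a sulfonyl sulfur gives a 1.2-fold higher number from compound 1 to compound 4 (0.09 log units; within the scatter), the first one-place step. At this position, the 6 heavy atoms of the leaving group, including its nitrogen and its ether oxygen, are therefore not required for a value in this range, and a single carbon on the sulfonyl sulfur serves as well within the scatter. Nothing measured here accounts for the two compounds standing level.

As far as these compounds go, whether an amino group, a morpholine or a longer chain such as butyl on the same sulfur would also stand level with compound 1 and compound 4 stays open. Compound 2 and compound 3 each differ from compound 1 in more than one place, so they settle none of this.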